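A few compounds are considered here, and "the series" means these few. Any claim that something is new, unique, unknown or untested is made for them only; others in the source may bear on it.

Measured in a physicochemical assay for acid dissociation:
compound 1, `COc1cccc(CNCCCNc2ccnc3cc(Oc4ccc(Cl)cc4)ccc23)c1O`, gives 9.28
compound 2, `COc1ccc(F)cc1CNCCCNc1ccnc2cc(CC(C)C)ccc12`, gives 9.47

Compound 1 has the lowest of the two numbers, but its nearest neighbour, compound 2, lies only a little higher, and that gap is within the scatter of this assay, so the two measured compounds cannot be told apart on these numbers.

Compound 3, `COc1cccc(CNCCCNc2ccnc3cc(Oc4ccccc4)ccc23)c1O`, differs from compound 1 in one place: hydrogen in place of chloro on an aromatic carbon. The aromatic carbon that carries the change sits on a six-membered aromatic ring of carbon only, para to a large group, on the 4-chlorophenoxy arm of the shared core, which thereby becomes a phenoxy arm. Among the measured compounds shown here, no step between measured compounds shows what removing a chloro here does.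

Given how far this ring stands from the rest of the shared core, the step from compound 1 to compound 3 in this assay is expected to be small, a number 0.05 log units higher from compound 1 to compound 3 (within the scatter), of no clear direction beyond the scatter. Compound 3 is therefore expected to give about 9.33, within 9.05 to 9.6.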

Compound 3, acid dissociation constant: 9.28
Beside the measured number, compound 3's estimate is 0.05 log units above it; the range from low to high includes it.
By their numbers in this assay, from the lowest: compounds 1, 3 and 2 (each within the scatter of the next).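

Replacing chloro with hydrogen on the 4-chlorophenoxy arm gives, in this assay, no change at the digits printed from compound 1 to compound 3 (within the scatter). Among the compounds shown here, this is the first step read at this position, where the earlier compounds offered only two numbers from compounds that differ in more than one place, and it shows that in this pair the change from a 4-chlorophenoxy to a phenoxy arm leaves no mark on the read-out beyond the scatter. No information at hand bears on why the step comes out this way.

The compounds shown leave open whether a different group on this same aromatic carbon, such as an amine or a carboxylic acid, would also leave the number in this assay within the scatter, since chloro and hydrogen are the only two substituents seen here. They also leave open whether a change elsewhere on the shared core, such as a longer chain in place of the one that carries the two nitrogens, would move this number, and whether the flat step holds beyond this single pair.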